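The source may hold more compounds than are shown below. What is called first, only, known or untested is meant among the compounds shown, and "the series" means these compounds.

Of the compounds shown here, three sharing one core have been measured in an in vitro functional assay on cells for agonist activity at Bombesin receptor subtype-3 (Mus musculus), read by luminescence and calcium flux; on this read-out lower numbers stand for an effect already at smaller amounts and higher numbers for an effect only at larger amounts of compound. Compound 1 `O=C(O)c1ccccc1-c1ccc(CCc2ncc(CCC3CCCCC3)[nH]2)cc1` gives 33 nM. Compound 2 `O=C(O)c1ccccc1-c1ccc(CCc2ncc(CC3CCC3)[nH]2)cc1` gives 7.1 nM, and compound 3 `CCCCc1cnc(CCc2ccc(-c3ccccc3C(=O)O)cc2)[nH]1` gives 93 nM. Compound 1 therefore stands second highest of the three numbers: its nearest neighbour is compound 3, and the step of a 2.8-fold higher number from compound 1 to compound 3 (0.45 log units; beyond the scatter) is modest, while the step of a 4.6-fold lower number from compound 1 to compound 2 (0.67 log units; beyond the scatter) is the larger one. Both steps come from changing the same group on the saturated chain carbon bound to an aromatic carbon.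

Compound 4 `Cc1ccc(Cc2cnc(CCc3ccc(-c4ccccc4C(=O)O)cc3)[nH]2)cc1` differs from compound 1 in that same place: 4-methylphenyl in place of cyclohexylmethyl on a saturated chain carbon bound to an aromatic carbon. The group that enters keeps the count of heavy atoms of the group that leaves but trades a six-membered non-aromatic ring of carbon only for a six-membered aromatic ring of carbon only. For the measured compounds named here, the measured steps bear only loosely on this change: the step of a 4.6-fold lower number from compound 1 to compound 2 (0.67 log units; beyond the scatter) and the step of a 2.8-fold higher number from compound 1 to compound 3 (0.45 log units; beyond the scatter) show that shrinking or stretching the group in this place moves the number in either direction by a modest amount, but no measured pair swaps a saturated ring for an aromatic one. With the size of the group retained, the expected step of a 1.1-fold lower number from compound 1 to compound 4 (0.04 log units; within the scatter) is none beyond the scatter, though the uncertainty is wide. Compound 4 is therefore estimated at 30 nM, within a range from 8 nM to 120 nM.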

Compound 4, half-maximal effective concentration: 162 nM
Beside the measured number, compound 4's estimate is 5.4-fold (0.73 log units) below it, outside the stated range (above it).
By their numbers in this assay, from the lowest: compound 2; then compound 1; then compounds 3 and 4 (each within the scatter of the next).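

In this assay this position proves sensitive to more than the size of the group: with the count of heavy atoms unchanged, trading the six-membered non-aromatic ring for a six-membered aromatic ring gives a 4.9-fold higher number from compound 1 to compound 4 (0.69 log units; beyond the scatter) and so moves the number away from the low end of the series rather than leaving it in place. The step of a 1.7-fold higher number from compound 3 to compound 4 (0.24 log units; within the scatter) lies within the scatter, so the open-chain group of compound 3 and the 4-methylphenyl group of compound 4 cannot be told apart here despite their different shapes, whereas the large step of a 23-fold higher number from compound 2 to compound 4 (1.36 log units; beyond the scatter) shows how far the series spreads at this one place, with compound 2 still holding the lowest number. Nothing measured on these compounds explains why the aromatic ring behaves differently from the saturated one.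

The compounds shown cannot separate the effect of the aromatic ring from that of its methyl group, so a plain phenyl ring remains an open case. On these data alone, it is also open whether a cyclopentyl ring would keep the low number of compound 2, and how an amine or a carboxylic acid on this group would read.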